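Fluoromethoxy in place of methoxy: a small lipophilicity shift

The source may report more compounds than this note shows. Statements on the series, on what has been measured and on what is new or still open speak of the compounds shown alone.

Compound 1, `COCC(COC)n1cc(Cl)nc(Nc2c(Cl)cc(OC)cc2Cl)c1=O`: 3.4
Compound 2, `COCC(COC)n1cc(Cl)nc(Nc2c(Cl)cc(OCF)cc2Cl)c1=O`: 3.1
Compound 3, `COCC(COC)n1cc(Br)nc(Nc2c(C)cc(OC)cc2C)c1=O`: 2.8

These three compounds were measured in a physicochemical assay for lipophilicity, using the shake flask method, in phosphate buffer, measured as octanol-water partition, at pH 7.4; on this read-out lower numbers stand for lower lipophilicity and higher numbers for higher lipophilicity. Compound 2 differs from compound 1 by fluoro in place of hydrogen on a saturated chain carbon bound to an oxygen on an aromatic ring, and this change gave a number 0.30 log units lower from compound 1 to compound 2 (within the scatter). Compound 3 sits on a different core; the difference between the two cores is not broken down here. Compound 4, `COCC(COC)n1cc(Br)nc(Nc2c(C)cc(OCF)cc2C)c1=O`, has not yet been measured. It differs from compound 3 by fluoro in place of hydrogen on a saturated chain carbon bound to an oxygen on an aromatic ring, the same change, at the same place, as between compound 1 and compound 2. Because a number 0.30 log units lower from compound 1 to compound 2 (within the scatter) was small, a similarly small step is expected from compound 3 to compound 4, namely a number 0.30 log units lower from compound 3 to compound 4 (within the scatter). On that basis compound 4 is estimated to give 2.5 in this assay, with a likely range from 2.1 to 2.9.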

Compound 4, distribution coefficient: 2.9
Compound 4: middle estimate off by 0.40 log units, on the low side; measured number inside the range.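

In this assay, fluoromethoxy in place of methoxy gave a number 0.30 log units lower from compound 1 to compound 2 (within the scatter) on the core of compound 1 and a number 0.10 log units higher from compound 3 to compound 4 (within the scatter) on the core of compound 3. So the step stayed small on both cores, which supports carrying this change between these two cores when only a small step on this read-out is wanted, but two pairs cannot show that the change has no effect at all or that it stays small on every core in the series. Nothing shown here bears on what lies behind either step.

The compounds shown leave open how the same change behaves on a core carrying an amine or a carboxylic acid. They also leave open whether a longer chain, such as ethoxy turned into fluoroethoxy, would give a similarly small step.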